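The source may report more compounds than this note shows. Statements on the series, on what has been measured and on what is new or still open speak of the compounds shown alone.

In a functional assay on MCF7 cells (Homo sapiens) for antiproliferative activity (a higher number here means a weaker inhibitor, a lower number a stronger inhibitor), compound 1 `CC(=O)Oc1ccc(C(=O)Nc2cc3ccc(OCC4CCCNC4)c(C)c3oc2=O)cc1CC=C(C)C` gives 820 nM, compound 2 `CC(C)=CCc1cc(C(=O)Nc2cc3ccc(OCCC4CCCCN4)c(C)c3oc2=O)ccc1O` gives 710 nM and compound 3 `CC(C)=CCc1cc(C(=O)Nc2cc3ccc(OCC4CCCNC4)c(C)c3oc2=O)ccc1O` gives 790 nM, so compound 3 lies within the scatter of both others. Compound 4 `CC(C)=CCc1cc(C(=O)Nc2cc3ccc(OCCCN4CCCCC4)c(C)c3oc2=O)ccc1O` carries 2-(piperidin-1-yl)ethyl in place of piperidin-3-yl on a saturated chain carbon bound to an oxygen on an aromatic ring. The closest measured change, at that same place, is a 1.1-fold higher number from compound 2 to compound 3 (0.05 log units; within the scatter). The swap of acetyl for hydrogen, a 1.0-fold lower number from compound 1 to compound 3 (0.02 log units; within the scatter), lies at another place. For the measured compounds named here, neither exceeds the scatter, so no step beyond it is expected in this assay, although no measured compound carries the entering group. The expected change is a 1.1-fold lower number from compound 3 to compound 4 (0.02 log units; within the scatter). For compound 4 the estimated value is 750 nM, within an expected range of 350 nM to 1600 nM.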

Compound 4, half-maximal inhibitory concentration: > 50000 nM
Compound 4: only a limit was reported (the forecaster's own chance of this, stated with the estimate: 2%); middle value at least 66-fold (1.82 log units) from the limit.
By their numbers in this assay, from the lowest: compounds 2, 3 and 1 (each within the scatter of the next). At a limit, above all of these: compound 4.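

Compound 4 gives only a limit in this assay: the limit of > 50000 nM in this assay, at which 1 of the 4 values shown sits.

The place on the saturated chain carbon bound to an oxygen on an aromatic ring had shown no step beyond the scatter, yet it proves sensitive to the group it carries, with an at least 63-fold higher number from compound 3 to compound 4 (1.80 log units; beyond the scatter) and an at least 70-fold higher number from compound 2 to compound 4 (1.84 log units; beyond the scatter). The change from piperidin-3-yl to 2-(piperidin-1-yl)ethyl adds heavy atoms and takes the group's hydrogen-bond donors from 1 to 0.

The compounds shown do not separate these two differences. Going by these compounds, whether a shorter chain ending in piperidin-1-yl would behave like compound 3 or like compound 4 stays open.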